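Notes on compound 4: dipropylamino in place of acetamido

The source may report more compounds than this note shows. Statements on the series, on what has been measured and on what is new or still open speak of the compounds shown alone.

Three compounds carry numbers in a functional assay on the whole organism with Rattus norvegicus as the target, at a dose of 40 mg/kg by the intraperitoneal route; a lower number here means less inhibition, a higher number more inhibition at the dose given (going by the name of the read-out). Compound 1 `CC(C)c1nc2c(OCc3ccccc3)cccn2c1N` gives 0%, and compound 2 `Cc1nc2c(OCCc3ccccc3)cccn2c1N` gives 56%. Compound 3 `CC(=O)Nc1c(C)nc2c(OCc3ccccc3)cccn12` gives 93%, the highest of the three; compound 2 is nearest and compound 1 furthest, both beyond the scatter. Within the data shown here, no pair of measured compounds differs in one place, so no single change has a measured effect.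

Compound 4 `CCCN(CCC)c1c(C)nc2c(OCc3ccccc3)cccn12` differs from compound 3 in one place: dipropylamino in place of acetamido on an aromatic carbon. The hydrogen-bond donor of the acetamido is lost. A fall is expected for a number 43 percentage points lower from compound 3 to compound 4 (beyond the scatter), beyond the scatter, because compound 1 at 0% and compound 2 at 56% both lack the acetamido and sit lower. Compound 4 is estimated at 50%, ranging from 10% to 85%.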

Compound 4, a percentage reported as inhibition, in the whole organism at one dose (the size of the read-out at that dose, not a potency): 60%
The estimate for compound 4 lay 10 percentage points below the measured number; measured number inside the range.
By their numbers in this assay, from the lowest: compound 1; then compounds 2 and 4 (each within the scatter of the next); then compound 3.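

Among these compounds, this is the first single-place change with a measured effect: in this assay, dipropylamino in place of acetamido on the aromatic carbon gives a number 33 percentage points lower from compound 3 to compound 4 (beyond the scatter) as a large step. The group at this position therefore matters for the read-out, yet compound 4 still gives 60% at this dose, so the acetamido is not required for inhibition. Nothing measured here accounts for the step, so neither the lost hydrogen-bond donor nor the larger group can be singled out.

Open, as far as these compounds go, is where dimethylamino or the unsubstituted amine would fall at this position on the core of compound 3. Also open, from the compounds shown here alone, is whether a longer acyl chain, such as butanamido, would hold the number of compound 3.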